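Swapping the Five-Membered Aromatic Ring on a Shared Core

The source may hold more compounds than are shown below. What is called first, only, known or untested is meant among the compounds shown, and "the series" means these compounds.

Three measured compounds share one core and differ only in the five-membered aromatic ring on an aromatic carbon. In an ADME assay on BJ cells (Homo sapiens) for cytotoxicity, read by MTT assay, with a stated time of 72 h (on this read-out higher numbers stand for lower toxicity in this test and lower numbers for higher toxicity in this test), compound 1 `OC[C@H]1O[C@@H](n2cc(F)c3c(-c4cccs4)ncnc32)[C@H](O)[C@@H]1O`, with thiophen-2-yl, gives 170 nM. Compound 2 `OC[C@H]1O[C@@H](n2cc(F)c3c(-c4ccsc4)ncnc32)[C@H](O)[C@@H]1O`, with thiophen-3-yl, gives 620 nM. Compound 3 `OC[C@H]1O[C@@H](n2cc(F)c3c(-c4ccc[nH]4)ncnc32)[C@H](O)[C@@H]1O`, with 1H-pyrrol-2-yl, gives 2990 nM, the highest number of the three and so the lowest toxicity in this assay.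

Compound 4 `OC[C@H]1O[C@@H](n2cc(F)c3c(-c4nccs4)ncnc32)[C@H](O)[C@@H]1O` has not yet been measured. It carries 1,3-thiazol-2-yl in place of 1H-pyrrol-2-yl on an aromatic carbon.

Two measured steps lead to the 1H-pyrrol-2-yl compound: the large 18-fold higher number from compound 1 to compound 3 (1.25 log units; beyond the scatter) and the modest 4.8-fold higher number from compound 2 to compound 3 (0.68 log units; beyond the scatter). Both lie beyond the scatter, so the two sulfur-bearing groups sit below compound 3. Going by the values given here, the entering 1,3-thiazol-2-yl also holds sulfur, which points to a lower number, but no measured compound carries this group. The modest 3.6-fold higher number from compound 1 to compound 2 (0.56 log units; beyond the scatter) shows that sulfur-bearing groups can themselves differ, so the size of the drop remains uncertain. The expected step is a modest one, estimated as a 3.0-fold lower number from compound 3 to compound 4 (0.48 log units; beyond the scatter). Compound 4 is estimated at 1000 nM, with an expected range from 250 nM to 4000 nM.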

Compound 4, half-maximal cytotoxic concentration: 630 nM
Beside the measured number, compound 4's estimate is 1.6-fold (0.20 log units) above it, within the range that was stated.
By their numbers in this assay, from the lowest: compound 1; then compounds 2 and 4 (each within the scatter of the next); then compound 3.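

Going by these compounds alone, with 1,3-thiazol-2-yl at this position, a 4.7-fold lower number from compound 3 to compound 4 (0.68 log units; beyond the scatter) in this assay, so a third sulfur-bearing group now sits below the 1H-pyrrol-2-yl group, which remains the only group here without sulfur. The new group does not match the other group joined through the same ring position, as a 3.7-fold higher number from compound 1 to compound 4 (0.57 log units; beyond the scatter) shows, so sulfur in the ring does not by itself set the number, and thiophen-2-yl remains apart from the 1,3-thiazol-2-yl group. Yet a 1.0-fold higher number from compound 2 to compound 4 (0.01 log units; within the scatter) places 1,3-thiazol-2-yl and thiophen-3-yl within the scatter of each other, so this assay does not separate these two different rings, and nothing measured here bears on why the groups fall as they do.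

As far as these compounds go, whether a sulfur-free 1H-imidazol-2-yl group would stay with compound 3 or fall with the sulfur-bearing groups remains open. So does the outcome for 1-methyl-1H-pyrrol-2-yl, a six-membered phenyl ring or an open-chain amine at this position.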